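A fourth stereoisomer of the hydroxyproline dipeptide in gastric fluid

The source may report more compounds than this note shows. Statements on the series, on what has been measured and on what is new or still open speak of the compounds shown alone.

Three stereoisomers of one dipeptide have been measured: compound 1 `O=C(O)[C@H](CO)NC(=O)[C@H]1C[C@H](O)CN1`, compound 2 `O=C(O)[C@@H](CO)NC(=O)[C@H]1C[C@@H](O)CN1` and compound 3 `O=C(O)[C@H](CO)NC(=O)[C@H]1C[C@@H](O)CN1`. In an ADME assay for metabolic stability, read by HPLC, in simulated gastric fluid, with a stated time of 12 h, at pH 1.2 (on this read-out lower numbers stand for a shorter-lived compound and higher numbers for a longer-lived compound), compound 1 gives > 12 h, which is a limit of the assay and not a number. Compound 2 in this assay gives > 12 h, again a limit. Compound 3 gives > 12 h, also a limit. The three steps among them, a step that the two limits leave unreadable from compound 1 to compound 2, a step that the two limits leave unreadable from compound 1 to compound 3 and a step that the two limits leave unreadable from compound 2 to compound 3, cannot be sized because every value sits at the same ceiling (the limit of > 12 h in this assay, at which 3 of the 3 values shown sit), even though each pair differs only in configuration as drawn the fact that compounds 1 and 2 differ only in the configuration as drawn the fact that compounds 1 and 3 differ only in the configuration as drawn (the fact that compounds 2 and 3 differ only in the configuration as drawn).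

Compound 4 `O=C(O)[C@H](CO)NC(=O)[C@@H]1C[C@H](O)CN1` is the remaining stereoisomer. Its change from compound 1 is the two compounds have the same atoms and bonds and differ only in configuration as drawn: 1 of 3 stereo elements differ; a stereocentre at a saturated ring carbon is drawn R in compound 1 and S in compound 4. Within the data shown here, the only measured steps that bear on it are the three configurational steps above, and none of them revealed a drop below the ceiling, so the data offer no reason to expect a readable change in either direction; the step is expected to be a step that the limit leaves unreadable from compound 1 to compound 4. Compound 4 is therefore estimated to give 15 h in this assay, within 9 h to 30 h, most probably reported again as a limit.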

Compound 4, half-life: > 12 h
Compound 4: a limit, no number; the forecaster's own chance of this, stated with the estimate: 85%; the middle value lies beyond the limit too.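

In this assay compound 4 sits at the same limit as compounds 1, 2 and 3, so none of the steps from compound 4 to those three compounds can be read: the limit of > 12 h in this assay, at which 4 of the 4 values shown sit. The compounds shown leave open whether these four stereoisomers differ in half-life at all.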